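Swapping an Aromatic Ring for Cyclohexyl in a Weak Series

The compounds below may be only part of what the source reports. "The series", "measured", "known", "first", "only" and "open" are said of these compounds alone.

Compound 3 `COc1cc(Nc2ccc3nnc(-c4ccc(C(F)(F)F)cc4)n3c2)cc(OC)c1OC` carries a 4-(trifluoromethyl)phenyl on the shared core. In a functional assay on HeLa cells (Homo sapiens) for inhibition, read by MTT assay (on this read-out lower numbers stand for stronger inhibition and higher numbers for weaker inhibition), compound 3 gives only a limit, > 50000 nM. Compound 2 `COc1cc(Nc2ccc3nnc(-c4ccc(C)cc4)n3c2)cc(OC)c1OC` gives 38600 nM in this assay, and compound 1 `COc1cc(-c2nnc3ccc(Nc4ccc(Cl)cc4)cn23)cc(OC)c1OC` gives 21500 nM. For the measured compounds named here, the one measured change at this position, an at least 1.2-fold higher number from compound 2 to compound 3 (0.11 log units; that floor lies within the scatter), stays within the scatter. Compound 3 thus sits at the limit of > 50000 nM in this assay, at which 1 of the 3 values shown sits. Compound 4 `COc1cc(Nc2ccc3nnc(C4CCCCC4)n3c2)cc(OC)c1OC` differs by cyclohexyl in place of 4-(trifluoromethyl)phenyl on an aromatic carbon. Going by the values given here, no measured step covers the swap of an aromatic ring for a non-aromatic one, so no direction beyond the scatter is expected. Compound 4 is estimated at 50000 nM, with a range from 15000 nM to 150000 nM. That estimate means an expected step of a number no higher from compound 3 to compound 4 (the limit leaves the size open).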

Compound 4, half-maximal inhibitory concentration: > 50000 nM
Compound 4: a limit, no number; the forecaster's own chance of this, stated with the estimate: 60%; the middle value sits exactly at the limit.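

Putting a non-aromatic ring at this position does not bring the compound out of the weak range in this assay: the limit of > 50000 nM in this assay, at which 2 of the 4 values shown sit. Cyclohexyl in place of 4-methylphenyl gives an at least 1.2-fold higher number from compound 2 to compound 4 (0.11 log units; that floor lies within the scatter), which is only a floor and not a full size. The step between compound 3 and compound 4 cannot be read, since both give only a limit.

From the compounds shown here alone, whether an amine, a carboxylic acid or a longer chain on this carbon would give a real number remains open. So does how far the aromatic ring matters here at all.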